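The source may report more compounds than this note shows. Statements on the series, on what has been measured and on what is new or still open speak of the compounds shown alone.

Measured so far:
compound 1 `Cc1nc(SCC(=O)Nc2nc(-c3ccc(Cl)cc3)cs2)n(Nc2ccccc2)c1C`: 58800 nM
compound 2 `Cc1ccc(Nn2c(SCC(=O)Nc3nc(-c4ccccc4)cs3)nc(C)c2C)cc1`: > 100000 nM (a limit of the assay)

Compound 1 holds the only numerical result here: in a functional assay on SF-268 cells (Homo sapiens) for antiproliferative activity, read by sulforhodamine B assay, with a stated time of 48 h (on this read-out lower numbers stand for higher toxicity in this test and higher numbers for lower toxicity in this test), compound 1 gives 58800 nM. Compound 2 gives only a limit of the assay in this assay, > 100000 nM, as recorded in the limit of > 100000 nM in this assay, at which 1 of the 2 values shown sits. For the measured compounds named here, no step between measured compounds that differ in one place exists in this set.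

Compound 3 `COc1ccc(Nn2c(SCC(=O)Nc3nc(-c4ccc(Cl)cc4)cs3)nc(C)c2C)cc1` differs from compound 1 by methoxy in place of hydrogen on an aromatic carbon. Going by the values given here, with no comparable measured step, the expected step is a 1.2-fold higher number from compound 1 to compound 3 (0.08 log units; within the scatter), within the usual scatter. For compound 3 the estimate in this assay is 70000 nM, ranging from 30000 nM to 160000 nM, with a real chance of only a limit.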

Compound 3, concentration lethal to 50% of the cells: > 100000 nM
Compound 3: only a limit was reported; the forecaster's own chance of this, stated with the estimate: 40%; at least 1.4-fold (0.15 log units) between middle value and limit.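

For the compounds shown here, on the anilino ring, methoxy in place of hydrogen on the aromatic carbon para to a large group gives the first readable step of the set in this assay: an at least 1.7-fold higher number from compound 1 to compound 3 (0.23 log units; that floor lies within the scatter). The result for compound 3, > 100000 nM, is a limit of the assay, which makes this step a floor and not a size. Results at the limit now form the majority of the set: the limit of > 100000 nM in this assay, at which 2 of the 3 values shown sit.

From the compounds shown here alone, whether methoxy at this position truly changes the read-out stays open. Also open, going by these compounds, is how an amine or a carboxylic acid on the same carbon would read.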